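The source may hold more compounds than are shown below. What is called first, only, known or untested is meant among the compounds shown, and "the series" means these compounds.

Measured so far in a physicochemical assay for lipophilicity, measured as octanol-water partition; a higher number here means a more lipophilic compound, a lower number a more polar compound:
- compound 1 `CC1=C(C(=O)OCc2cccnc2)C(c2ccc(C#N)cc2)C2=C(CCCC2=O)N1`: 1.36
- compound 2 `CC1=C(C(=O)OCc2ccccn2)C(c2ccc(C#N)cc2)C2=C(CCCC2=O)N1`: 1.73
- compound 3 `CC1=C(C(=O)OCc2cccnc2)C(c2ccccc2[N+](=O)[O-])C2=C(CCCC2=O)N1`: 1.51

Compound 2 lies beyond the scatter above compound 1, but within the scatter of compound 3, so it has no clear lead over every other compound. The next compound to be measured is compound 4 `COc1ccc(C2C(C(=O)OCc3ccccn3)=C(C)NC3=C2C(=O)CCC3)cc1`, which differs from compound 2 in one place: methoxy in place of cyano on an aromatic carbon. In words, methoxy stands in place of cyano on an aromatic carbon, which turns 4-cyanophenyl into 4-methoxyphenyl.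

Among the compounds with values here, no measured step makes this exact swap, so the evidence is indirect. Replacing pyridin-3-yl with pyridin-2-yl gave a number 0.37 log units higher from compound 1 to compound 2 (beyond the scatter), but that change lies elsewhere in the molecule. Replacing 4-cyanophenyl with 2-nitrophenyl gave a number 0.15 log units higher from compound 1 to compound 3 (within the scatter). That step also removes the cyano group, yet it stays small, and it brings in no methoxy.

Within the data shown here, no measured compound carries methoxy, so the upward direction is a judgement from the swap itself, and no change at all remains possible. A modest rise is expected, with the estimated step being a number 0.37 log units higher from compound 2 to compound 4 (beyond the scatter). For compound 4 the estimated value is 2.1, with an expected range from 1.7 to 2.5.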

Compound 4, partition coefficient: 1.9
The estimate for compound 4 lay 0.20 log units above the measured number, and the stated range covers the measured number.
By their numbers in this assay, from the lowest: compounds 1, 3, 2 and 4 (each within the scatter of the next, the first and the last beyond it).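

In this assay, the swap of cyano for methoxy on this aromatic carbon, para to a large group, gives a number 0.17 log units higher from compound 2 to compound 4 (within the scatter), so the change from 4-cyanophenyl to 4-methoxyphenyl cannot be told apart from repeat-measurement noise in this series. This is the second change at this aryl group to stay within the scatter, after a number 0.15 log units higher from compound 1 to compound 3 (within the scatter), while the one step beyond it among these compounds, a number 0.37 log units higher from compound 1 to compound 2 (beyond the scatter), lies at the pyridine end of the molecule. Cyano and methoxy match in the simple counts, each with 2 heavy atoms and 1 hydrogen-bond acceptor, and nothing available here explains the size of this step.

Still open, on these data alone, is whether the same swap gives a similar step when the ester carries pyridin-3-yl instead of pyridin-2-yl, since methoxy appears here with only one of the two. Also open, as far as these compounds go, is whether a quite different group on this aromatic carbon, such as an amine, a carboxylic acid or a longer alkoxy chain, would move the number beyond the scatter.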